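A few compounds are considered here, and "the series" means these few. Any claim that something is new, unique, unknown or untested is made for them only; others in the source may bear on it.

In a functional assay on HCT-15 cells (Homo sapiens) for cytotoxicity (on this read-out lower numbers stand for stronger inhibition and higher numbers for weaker inhibition), compound 1 `Cc1ccc2c(O)nc(-c3ccccc3)cc2c1` gives 5130 nM, and compound 2 `Cc1ccc(-c2cc3cc(C)ccc3c(O)n2)cc1` gives 35500 nM, the higher of the two numbers. Among the compounds with values here, the only measured step, a 6.9-fold higher number from compound 1 to compound 2 (0.84 log units; beyond the scatter), is methyl in place of hydrogen on an aromatic carbon. Compound 3 `Cc1ccc(-c2cc3cc(C)ccc3c(N3CCN(C)CC3)n2)cc1` instead carries 4-methylpiperazin-1-yl in place of hydroxy on an aromatic carbon, next to the ring nitrogen: 4-methylpiperazin-1-yl in place of hydroxy on an aromatic carbon. Within the data shown here, no measured step covers this replacement, so the methyl step bears on scale only. Going by a 6.9-fold higher number from compound 1 to compound 2 (0.84 log units; beyond the scatter), a step of similar or larger size is expected in this assay for this bigger exchange. Among the measured compounds shown here, its direction is uncertain, but a lower number is expected, with compound 2 at 35500 nM the higher of the two so far. The estimated step is an 8.9-fold lower number from compound 2 to compound 3 (0.95 log units; beyond the scatter). The estimate for compound 3 is 4000 nM, with an expected range of 700 nM to 25000 nM.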

Compound 3, half-maximal inhibitory concentration: 8320 nM
For compound 3 the middle estimate is 2.1-fold (0.32 log units) below the measured one; the range from low to high includes it.
By their numbers in this assay, from the lowest: compounds 1 and 3 (each within the scatter of the next); then compound 2.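

In this assay, the aromatic carbon next to the ring nitrogen accepts a much larger group than hydroxy: the exchange for 4-methylpiperazin-1-yl gives a 4.3-fold lower number from compound 2 to compound 3 (0.63 log units; beyond the scatter). Within the data shown here, this is the first measured change at this position, and it shows that hydroxy is not needed here for a number at this level, since the entering group carries 0 hydrogen-bond donors. No supporting measurement is available to explain the step.

Open, on these data alone, is whether a smaller amine such as dimethylamino, a morpholin-4-yl ring or a methoxy group at this position would give a similar number, or whether the full 4-methylpiperazin-1-yl group is required. Also open, as far as these compounds go, is how 4-methylpiperazin-1-yl behaves on the core of compound 1, and whether the methyl step and this exchange add up.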